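This account rests on a few compounds, and the source may have more. Where it says the series, first, only, none or still open, it means among the compounds named here.

Compound 1, `COC[C@H](C)[C@H](C)C(c1ccc(O)c(OC)c1)c1ccc(O)c(OC)c1`: in a functional assay on HL-60 cells (Homo sapiens) for cytotoxicity, read by WST assay, with a stated time of 48 h (a lower number here means a stronger inhibitor, a higher number a weaker inhibitor), compound 1 gives 82000 nM.
Compound 2, `COc1cc(C(c2ccc(O)c(OC)c2)[C@H](C)[C@H](C)CO)ccc1O`: in this assay compound 2 sits at > 100000 nM, a limit of the assay and not a number.
Compound 3, `COc1cc(C(c2ccc(O)c(OC)c2)[C@H](CF)C(C)C)ccc1O`: in this assay compound 3 gives 19000 nM.

Among the two numbers, compound 1 stands highest; its nearest neighbour is compound 3, with a 4.3-fold lower number from compound 1 to compound 3 (0.64 log units; beyond the scatter). Compound 2 is at the limit (the limit of > 100000 nM in this assay, at which 1 of the 3 values shown sits), so its distance from compound 1 is known only as an at least 1.2-fold higher number from compound 1 to compound 2 (0.08 log units; that floor lies within the scatter), and from compound 3 as an at least 5.2-fold lower number from compound 2 to compound 3 (0.72 log units; beyond the scatter).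

Compound 4, `COC[C@@H](C)[C@@H](C)C(c1ccc(O)c(OC)c1)c1ccc(O)c(OC)c1`, differs from compound 1 in this way: the two compounds have the same atoms and bonds and differ only in configuration as drawn: 2 of 2 stereo elements differ (all stereocentres are inverted: mirror images); a stereocentre at a saturated chain carbon is drawn R in compound 1 and S in compound 4; a stereocentre at a saturated chain carbon is drawn R in compound 1 and S in compound 4. Every measured step exchanges the substituent on the saturated chain carbon bound to two aromatic carbons; none of them inverts a stereocentre, so none bears directly on this change. Among the compounds with values here, with no measured mirror-image pair to lean on, the expectation for compound 4 is a number near that of compound 1, with no step beyond the scatter, a 1.0-fold lower number from compound 1 to compound 4 (0.01 log units; within the scatter). Compound 4 is therefore estimated at 80000 nM, between 30000 nM and 200000 nM.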

Compound 4, half-maximal inhibitory concentration: 85000 nM
Compound 4: middle estimate off by 1.1-fold (0.03 log units), on the low side; measured number inside the range.
By their numbers in this assay, from the lowest: compound 3; then compounds 1 and 4 (each within the scatter of the next). At a limit, above all of these: compound 2.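

Inverting both stereocentres of compound 1 leaves the two forms within the scatter of each other in this assay (a 1.0-fold higher number from compound 1 to compound 4 (0.02 log units; within the scatter)), so at this position the configuration as drawn does not separate the pair: the fact that compounds 1 and 4 differ only in the configuration as drawn. The exchange of substituent still counts against this mirror-image form as it did against compound 1 (a 4.5-fold higher number from compound 3 to compound 4 (0.65 log units; beyond the scatter)), which leaves compound 3 apart from both forms. Compound 2 stands at a limit and not a number, so the step from it is known only as a floor (an at least 1.1-fold lower number from compound 2 to compound 4 (0.07 log units; that floor lies within the scatter)): the limit of > 100000 nM in this assay, at which 1 of the 4 values shown sits.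

Going by these compounds, what remains open is whether inverting only one of the two stereocentres would leave the number as unchanged, and whether the mirror image of compound 3 would match compound 3. Also open, on these data alone, is how an amine or a longer alkyl chain would read on the saturated chain carbon bound to two aromatic carbons.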